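A few compounds are considered here, and "the series" means these few. Any claim that something is new, unique, unknown or untested is made for them only; others in the source may bear on it.

Of the compounds shown here, three built on one shared core have been measured in a physicochemical assay for lipophilicity; on this read-out lower numbers stand for lower lipophilicity and higher numbers for higher lipophilicity. Compound 1 `Cc1cc(=O)[nH]c2cc(NC(=O)c3cccc4ccccc34)ccc12` gives 1.72, and compound 2 `Cc1cc(=O)[nH]c2cc(NC(=O)/C=C/c3ccccc3)ccc12` gives 1.69. Compound 3 `CC(=O)Nc1ccc2c(C)cc(=O)[nH]c2c1` gives 0.995, the lowest of the three numbers; compound 2 and compound 1 both lie higher, beyond the usual scatter of this kind of measurement. Compound 4 `Cc1cc(=O)[nH]c2cc(NC(=O)c3ccc(Cl)cc3)ccc12` has not yet been measured. It differs from compound 3 in a single place: 4-chlorophenyl in place of methyl on a carbonyl carbon. Because compound 1 gives 1.72 and compound 2 gives 1.69, the step of a number 0.76 log units higher from compound 3 to compound 4 (beyond the scatter) is expected to be upward and clearly beyond the scatter. Compound 4 is therefore estimated at 1.75, with a likely range from 1.4 to 2.1.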

Compound 4, partition coefficient: 1.69
Estimate against measurement, compound 4: 0.06 log units above, within the range that was stated.
By their numbers in this assay, from the lowest: compound 3; then compounds 2, 4 and 1 (each within the scatter of the next).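

In this assay, this carbonyl carbon now has a direct single-change comparison: 4-chlorophenyl in place of methyl gives a number 0.70 log units higher from compound 3 to compound 4 (beyond the scatter), a modest step beyond the scatter. Compound 4 lies within the scatter of compound 2 and compound 1, so the three groups other than methyl at this place cannot be told apart on this read-out. Nothing available explains why the number moves with this change. From the compounds shown here alone, how a longer chain or an amine at this carbonyl carbon would compare remains open. So does whether a carboxylic acid on the ring of the 4-chlorophenyl group, in place of chlorine, would bring the number closer to that of compound 3.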